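Ester side chain variants on a shared core

This account rests on a few compounds, and the source may have more. Where it says the series, first, only, none or still open, it means among the compounds named here.

Three compounds of the series have numbers in a functional assay on NCI-H1975 cells (Homo sapiens) for inhibition, read by MTT assay, with a stated time of 72 h; a higher number here means a weaker inhibitor, a lower number a stronger inhibitor. Compound 1 `C=CC(=O)Oc1cc2c(Nc3ccc(F)c(Cl)c3)ncnc2cc1OCC` gives 700 nM. Compound 2 `CCOc1cc2ncnc(Nc3ccc(F)c(Cl)c3)c2cc1OC(=O)CSc1ncccn1` gives 3600 nM, and compound 3 `CCOc1cc2ncnc(Nc3ccc(F)c(Cl)c3)c2cc1OC(=O)CSc1ncc[nH]1` gives 1400 nM. The steps between them read a 5.1-fold higher number from compound 1 to compound 2 (0.71 log units; beyond the scatter), a 2.0-fold higher number from compound 1 to compound 3 (0.30 log units; within the scatter) and a 2.6-fold lower number from compound 2 to compound 3 (0.41 log units; beyond the scatter). Compound 3 thus stands second highest of the three numbers, with compound 1 within the scatter of it and compound 2 beyond it on the higher side.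

Compound 4 `CCOc1cc2ncnc(Nc3ccc(F)c(Cl)c3)c2cc1OC(=O)CSc1nc2ccccc2s1` differs from compound 3 in one place: 1,3-benzothiazol-2-yl in place of 1H-imidazol-2-yl on a sulfur. Among the measured compounds shown here, the only measured step that bears on this is a 2.6-fold lower number from compound 2 to compound 3 (0.41 log units; beyond the scatter), in which the ring on the sulfur was exchanged and the number moved beyond the scatter. For the measured compounds named here, the change to compound 4 again exchanges the ring on the sulfur, now for the 1,3-benzothiazol-2-yl group with no hydrogen-bond donor, and the series holds no second example of such an exchange. Going by the values given here, a modest rise in the number is therefore expected, a 2.0-fold higher number from compound 3 to compound 4 (0.30 log units; within the scatter), rather than no step at all. Compound 4 is estimated at 2800 nM in this assay, with a range from 1200 nM to 7000 nM.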

Compound 4, half-maximal inhibitory concentration: 9800 nM
Estimate against measurement, compound 4: 3.5-fold (0.54 log units) below, and the stated range ends below it.
By their numbers in this assay, from the lowest: compounds 1 and 3 (each within the scatter of the next); then compound 2; then compound 4.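

In this assay the ring on the sulfur sets the number over a wider span than compounds 2 and 3 alone showed: 1,3-benzothiazol-2-yl in place of 1H-imidazol-2-yl gives a 7.0-fold higher number from compound 3 to compound 4 (0.85 log units; beyond the scatter) and in place of pyrimidin-2-yl gives a 2.7-fold higher number from compound 2 to compound 4 (0.43 log units; beyond the scatter) as the ring changes again. Among the compounds shown here, the sulfanylmethyl ester is therefore not tied to one level, since compound 3 lies within the scatter of the vinyl ester compound 1 while the benzothiazole gives the only large step with a 14-fold higher number from compound 1 to compound 4 (1.15 log units; beyond the scatter) on the same carbonyl carbon. No measurement at hand accounts for this rise.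

The exchange from compound 3 to compound 4 goes from 5 to 9 heavy atoms and from 1 hydrogen-bond donor to 0 in one move, so the compounds shown cannot separate the fused benzene ring from the loss of the ring hydrogen. Going by these compounds, a 1H-benzimidazol-2-yl or a plain phenyl on the same sulfur would bear on that question, and how an amine in place of the sulfur would read also remains open.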